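This account rests on a few compounds, and the source may have more. Where it says the series, first, only, none or still open, it means among the compounds named here.

Working notes on the series. Compound 3 `CC(C)(C)c1ccc(S(=O)(=O)Nc2ccc(Cl)cc2-c2nc(N)ncc2O)cc1` holds the lowest number in a functional assay on isolated protein for antagonist activity at C-C chemokine receptor type 9 (Homo sapiens), read by calcium flux, with a stated time of 10 min (on this read-out lower numbers stand for stronger inhibition and higher numbers for weaker inhibition), where compound 3 gives 4 nM; compound 2 `CC(C)(C)c1ccc(S(=O)(=O)Nc2ccc(Cl)cc2-c2nccc(C(N)=O)c2O)cc1` gives 52 nM and compound 1 `CC(C)(C)c1ccc(S(=O)(=O)Nc2ccc(Cl)cc2-c2ncccc2CN)cc1` gives 3160 nM. The measured steps are all large: a 790-fold lower number from compound 1 to compound 3 (2.90 log units; beyond the scatter), a 13-fold lower number from compound 2 to compound 3 (1.11 log units; beyond the scatter) and a 61-fold lower number from compound 1 to compound 2 (1.78 log units; beyond the scatter).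

Compound 4 `CC(C)(C)c1ccc(S(=O)(=O)Nc2ccc(Cl)cc2-c2ncnc(CO)c2O)cc1` differs from compound 3 by a group of 9 heavy atoms (5 carbon, 2 nitrogen, 2 oxygen; one six-membered aromatic ring with 2 hetero atoms) in place of a group of 8 heavy atoms (4 carbon, 3 nitrogen, 1 oxygen; one six-membered aromatic ring with 2 hetero atoms), on an aromatic carbon, on the aromatic carbon ortho to a large group and meta to the chloro group. Among the measured compounds shown here, no measured step exchanges one six-membered aromatic ring with 2 hetero atoms for another; the steps into compound 3 replaced rings with 1 hetero atom. Every measured change at this carbon moved this assay by more than the scatter, so a step beyond it is expected here too, most likely upward. Compound 4 is estimated at 20 nM, range 5 nM to 80 nM, a step of a 5.0-fold higher number from compound 3 to compound 4 (0.70 log units; beyond the scatter).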

Compound 4, half-maximal inhibitory concentration: 11 nM
The estimate for compound 4 lay 1.8-fold (0.26 log units) above the measured number; the range from low to high includes it.
By their numbers in this assay, from the lowest: compound 3; then compound 4; then compound 2; then compound 1.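

This exchange of one six-membered aromatic ring with 2 hetero atoms for another gives only a 2.8-fold higher number from compound 3 to compound 4 (0.44 log units; beyond the scatter) and leaves the counts of hydrogen-bond donors and acceptors equal, so this carbon accepts a second such ring at a modest loss. Against the rings with 1 hetero atom, a 4.7-fold lower number from compound 2 to compound 4 (0.67 log units; beyond the scatter) and a 290-fold lower number from compound 1 to compound 4 (2.46 log units; beyond the scatter) show that compound 4 keeps most of the gain seen with compound 3. Still open, going by these compounds, is whether a carboxylic acid or a longer chain in place of the hydroxymethyl group keeps the number this low. No evidence on hand bears on these steps.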